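This account rests on a few compounds, and the source may have more. Where it says the series, first, only, none or still open, it means among the compounds named here.

Of the compounds shown here, two have been tested so far in a functional assay on PC-3 cells (Homo sapiens) for antiproliferative activity, read by MTT assay, with a stated time of 72 h; on this read-out higher numbers stand for weaker inhibition and lower numbers for stronger inhibition. Compound 1, `COc1cc2ncnc(N3CCCc4ccccc43)c2cc1NC(=O)/C=C/C(C)C`, gives 8430 nM in this assay. Compound 2, `C/C=C/C(=O)Nc1cc2c(N3CCCc4ccccc43)ncnc2cc1O[C@@H]1CCOC1`, gives 9350 nM in this assay. On these two numbers compound 2 stands at the higher end, but its nearest neighbour is compound 1, and the gap between the two lies within the usual scatter of such measurements, so the two results cannot be told apart.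

The next compound, compound 3, has the structure `CC(C)/C=C/C(=O)Nc1cc2c(N3CCCc4ccccc43)ncnc2cc1O[C@@H]1CCOC1`. It is built from compound 2 by one change: isopropyl in place of methyl on a double-bonded chain carbon bound to a double-bonded chain carbon. In plainer words, isopropyl replaces methyl on a double-bonded chain carbon bound to a double-bonded chain carbon, so the chain grows by two carbons and nothing else about the molecule moves. For the measured compounds named here, no measured pair in this set isolates exactly this change, so no step size is known for it. The structure of compound 1, which already carries the larger 3-methylbut-1-en-1-yl group, gives a modest hint that the isopropyl group is tolerated in this assay. The expected step from compound 2 to compound 3 in this assay is therefore small, a 1.1-fold lower number from compound 2 to compound 3 (0.04 log units; within the scatter), and not beyond the scatter in either direction. Compound 3 is expected to give about 8500 nM in this assay, with a likely range from 4000 nM to 18000 nM.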

Compound 3, half-maximal inhibitory concentration: 8510 nM
For compound 3 the middle estimate is 1.0-fold (0.00 log units) below the measured one, within the range that was stated.
By their numbers in this assay, from the lowest: compounds 1, 3 and 2 (each within the scatter of the next).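

In this assay, isopropyl in place of methyl on a double-bonded chain carbon bound to a double-bonded chain carbon gives a 1.1-fold lower number from compound 2 to compound 3 (0.04 log units; within the scatter), so this swap leaves the result indistinguishable from that of the methyl compound. Compound 1 and compound 2 differ in two places at once, which hid the contribution of each place, but compound 3 now separates them: oxolan-3-yl in place of methyl on an oxygen on an aromatic ring gives a 1.0-fold higher number from compound 1 to compound 3 (0.00 log units; within the scatter), and this change also cannot be told from no change at all in this assay. No measurement is available that would account for either result.

Only methyl and isopropyl have been compared on the double-bonded chain carbon, and only methyl and oxolan-3-yl on the oxygen, so these results cannot say whether other groups at these places would also leave the number unmoved. A dimethylamino group or a longer chain on that carbon, or a chain ending in a carboxylic acid on that oxygen, would test whether either place can shift the number beyond the scatter.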